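The source may hold more compounds than are shown below. What is called first, only, known or untested is meant among the compounds shown, and "the series" means these compounds.

Among the three measured compounds, compound 3 `Cc1ccc(C(=O)/C=C/c2ccc3c(c2)B(O)OC3)cc1` gives the lowest number in a toxicity assay on MCF-10A cells (Homo sapiens) for cytotoxicity, read by MTT assay, with a stated time of 48 h (on this read-out lower numbers stand for stronger inhibition and higher numbers for weaker inhibition), with 8300 nM. Compound 1 `O=C(/C=C/c1ccc2c(c1)B(O)OC2)c1ccc(Cl)cc1` gives 12100 nM in this assay, and that pair lies within the scatter, a 1.5-fold lower number from compound 1 to compound 3 (0.16 log units; within the scatter). Compound 2 `O=C(/C=C/c1ccc2c(c1)B(O)OC2)c1ccc(Br)cc1` gives 27800 nM in this assay, and there the gap is real, a 3.3-fold lower number from compound 2 to compound 3 (0.52 log units; beyond the scatter); the remaining step, a 2.3-fold higher number from compound 1 to compound 2 (0.36 log units; beyond the scatter), is likewise beyond the scatter.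

Compound 4 `O=C(/C=C/c1ccc2c(c1)B(O)OC2)c1cccc(O)c1` differs from compound 3 in one place: 3-hydroxyphenyl in place of 4-methylphenyl on a carbonyl carbon. Going by the values given here, none of the measured steps makes this kind of exchange; each of them replaces chloro, bromo or methyl with another of these on an aromatic carbon, and even so the largest of them reached only a modest size. The exchange of a hydroxyl-bearing ring for a methyl-bearing ring has no precedent among these compounds, so the expectation rests on the narrow spread of the measured numbers alone. Compound 4 is therefore expected to stay close to compound 3, with a step of a 1.3-fold higher number from compound 3 to compound 4 (0.12 log units; within the scatter) in this assay that need not exceed the scatter. The estimate for compound 4 is 11000 nM, with a range from 4000 nM to 40000 nM.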

Compound 4, half-maximal inhibitory concentration: 25300 nM
Estimate against measurement, compound 4: 2.3-fold (0.36 log units) below; the range from low to high includes it.
By their numbers in this assay, from the lowest: compounds 3 and 1 (each within the scatter of the next); then compounds 4 and 2 (each within the scatter of the next).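

In this assay the ring on the carbonyl carbon proves able to shift the number when 3-hydroxyphenyl replaces 4-methylphenyl, with a 3.0-fold higher number from compound 3 to compound 4 (0.48 log units; beyond the scatter) as a modest step beyond the scatter. The outcome depends on which ring leaves: replacing 4-chlorophenyl gives a 2.1-fold higher number from compound 1 to compound 4 (0.32 log units; beyond the scatter) and is also beyond the scatter, whereas replacing 4-bromophenyl gives a 1.1-fold lower number from compound 2 to compound 4 (0.04 log units; within the scatter) and leaves compound 4 within the scatter of compound 2, so the hydroxyl-bearing ring does not stand apart from all the earlier rings. Nothing available explains these differences.

Whether the step belongs to the hydroxyl group or to its place on the ring stays open, as the compounds shown change both at once. Also open, going by these compounds, is how a ring bearing an amine or a carboxylic acid would read in this assay at this position.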